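The source may report more compounds than this note shows. Statements on the series, on what has been measured and on what is new or still open speak of the compounds shown alone.

Measured compounds:
- compound 1 `Cc1ccc(C2CNN=C2S(=O)(=O)CC2=NCCS2)cc1`: 48.6%
- compound 2 `O=S(=O)(CC1=NCCO1)C1=NNCC1c1ccccc1`: "not active" (no number reported)

The account follows the step from compound 2 to compound 3. In a functional assay, read by Griess assay, with a stated time of 150 min, tested at 75 ug/mL (on this read-out higher numbers stand for a stronger effect at the one concentration tested and lower numbers for a weaker effect), compound 2 gives "not active" (no number reported), so no single number places it on the scale; it stands simply as a compound for which no activity was reported. In this assay compound 1 gives 48.6%, but no step between compound 1 and compound 2 is shown, and the two values say only that one compound returned a number and the other did not.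

Compound 3 `Cc1ccc(C2CNN=C2S(=O)(=O)CC2=NCCO2)cc1` is the compound still to be measured in this assay. Compound 3 differs from compound 2 in one place: methyl in place of hydrogen on an aromatic carbon. For the measured compounds named here, the change is small, a methyl in place of hydrogen, and with no measured step of this kind to lean on, the expected size of the step in this assay is uncertain; a move in either direction, or none beyond the scatter, is possible. On the numbers shown, compound 3 is expected to give around 25% in this assay, within a range from 0% to 55%.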

Compound 3, a percentage reported as activity, at one concentration (the size of the read-out at that concentration, not a potency): 49.7%
The estimate for compound 3 lay 24.7 percentage points below the measured number; measured number inside the range.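

Compound 3 gives a number in this assay, while its phenyl counterpart, compound 2, is recorded as "not active" (no number reported), so the change from phenyl to 4-methylphenyl separates a compound with a reported activity from one without. Because compound 2 has no number, that step cannot be read as a size, and the effect of the methyl can only be described in these terms. The earlier compounds also left the five-membered non-aromatic ring on the saturated chain carbon untested as a single change, and with oxygen in place of sulfur in that ring the two compounds stand level, with a number 1.1 percentage points higher from compound 1 to compound 3 (within the scatter), while nothing on hand offers a reason for either observation.

The compounds shown leave open how an ethyl group, a methoxy group or a chlorine on the same aromatic carbon would read in this assay, and so whether the result belongs to methyl alone or to any group there. They also leave open whether the sulfur-containing ring paired with an unsubstituted phenyl would return a number, and how any of these compounds would behave at concentrations other than the single one tested.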